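Solubility notes: replacing the thiazolidinedione in compound 1

The compounds below may be only part of what the source reports. "The series", "measured", "known", "first", "only" and "open" are said of these compounds alone.

Compound 1 `O=C1CSC(=O)N1C[C@H]1CN(c2ccc(-n3cc(-c4ccccn4)cn3)c(F)c2)C(=O)O1` has the lowest number of the three measured in a physicochemical assay for solubility, read by HPLC, with a stated time of 24 h; on this read-out lower numbers stand for lower solubility and higher numbers for higher solubility; compound 1 gives 26900 nM. Its nearest neighbour is compound 3 `COC(=O)NC[C@H]1CN(c2ccc(-n3cc(-c4ccccn4)cn3)c(F)c2)C(=O)O1`, which in this assay gives 34100 nM, a gap that stays within the scatter, so no order between compound 1 and compound 3 is claimed. The furthest is compound 2 `CCC(=O)NC[C@H]1CN(c2ccc(-n3cc(-c4ccccn4)cn3)c(F)c2)C(=O)O1`, which in this assay gives 147000 nM. The measured steps are a 5.5-fold higher number from compound 1 to compound 2 (0.74 log units; beyond the scatter), a 1.3-fold higher number from compound 1 to compound 3 (0.10 log units; within the scatter) and a 4.3-fold lower number from compound 2 to compound 3 (0.63 log units; beyond the scatter).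

Compound 4 `CONC(=O)[C@H]1CN(c2ccc(-n3cc(-c4ccccn4)cn3)c(F)c2)C(=O)O1` differs from compound 1 by methoxycarbamoyl in place of (2,4-dioxo-1,3-thiazolidin-3-yl)methyl on a saturated ring carbon. Within the data shown here, the steps that bear on it are the two that remove the same 2,4-dioxo-1,3-thiazolidin-3-yl group in favour of an acyclic group carrying one hydrogen-bond donor: the step from compound 1 to compound 2 was modest and beyond the scatter, the step from compound 1 to compound 3 stayed within it. Among the measured compounds shown here, no measured step places the entering group directly on the ring carbon, and none shortens the chain, so the comparison is loose. A modest rise, or none beyond the scatter, is expected in this assay. Compound 4 is estimated at 50000 nM, with a range of 17000 nM to 150000 nM, which would mean an expected step of a 1.9-fold higher number from compound 1 to compound 4 (0.27 log units; within the scatter).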

Compound 4, solubility: 78100 nM
Beside the measured number, compound 4's estimate is 1.6-fold (0.19 log units) below it; the measured number falls inside the stated range.
By their numbers in this assay, from the lowest: compounds 1 and 3 (each within the scatter of the next); then compounds 4 and 2 (each within the scatter of the next).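

Moving the attachment onto the saturated ring carbon itself, with methoxycarbamoyl in place of (2,4-dioxo-1,3-thiazolidin-3-yl)methyl, gives in this assay a 2.9-fold higher number from compound 1 to compound 4 (0.46 log units; beyond the scatter), so this position still carries a measurable gain when the saturated chain carbon of the earlier compounds is gone. The same entering group also separates from the acyclic carbamate side chain, with a 2.3-fold higher number from compound 3 to compound 4 (0.36 log units; beyond the scatter), while against the propanoylamino side chain it shows a 1.9-fold lower number from compound 2 to compound 4 (0.27 log units; within the scatter), which leaves no order between those two compounds and shows that the upper level of the series is reached without the chain carbon. Nothing measured in this set accounts for any of these steps.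

The compounds shown do not separate the part played by losing the chain carbon from the part played by the exchange of the group, as compound 4 differs from the others in both at once. From the compounds shown here alone, how an amine, a carboxylic acid or a longer chain on the same saturated ring carbon would read in this assay also stays open.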